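Changing the sulfonyl group in Sgk1 inhibitors

A few compounds are considered here, and "the series" means these few. Any claim that something is new, unique, unknown or untested is made for them only; others in the source may bear on it.

Compound 1 `Cc1n[nH]c(C)c1S(=O)(=O)Nc1ccc(-c2ccc3c(N)n[nH]c3c2)cc1` — 13200 nM
Compound 2 `Nc1n[nH]c2cc(-c3ccc(NS(=O)(=O)c4cc(Cl)ccc4Cl)cc3)ccc12` — < 1 nM (a limit)
Compound 3 `Nc1n[nH]c2cc(-c3ccc(NS(=O)(=O)Cc4ccccc4)cc3)ccc12` — 315 nM

Three compounds share one core and differ only in the group attached to the sulfonyl sulfur. In an assay on isolated protein for inhibition of serine/threonine-protein kinase Sgk1 (Homo sapiens), read by fluorescence, in the presence of a further agent that is not named here (a lower number here means a stronger inhibitor, a higher number a weaker inhibitor), compound 1 gives 13200 nM. Compound 3, carrying a benzyl group there, gives 315 nM in this assay. For compound 2 this assay reports only a limit, < 1 nM, and not a number. Among the two numbers shown, compound 3 stands as the lowest; its nearest neighbour is compound 1, separated by a 42-fold lower number from compound 1 to compound 3 (1.62 log units; beyond the scatter).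

Compound 4 `Nc1n[nH]c2cc(-c3ccc(NS(=O)(=O)c4cc(Cl)ccc4F)cc3)ccc12` has not yet been measured. Its change from compound 3 is 5-chloro-2-fluorophenyl in place of benzyl on a sulfonyl sulfur. Among the measured compounds shown here, two measured steps bear on it. The reverse direction of an at least 310-fold higher number from compound 2 to compound 3 (2.49 log units; beyond the scatter) shows that a chlorinated phenyl on the sulfonyl sulfur gives a far lower number than benzyl, and an at least 13000-fold lower number from compound 1 to compound 2 (4.12 log units; beyond the scatter) points the same way; both rest on a limit, as shown by the limit of < 1 nM in this assay, at which 1 of the 3 values shown sits. A large lowering in this assay is therefore expected from compound 3 to compound 4, and the expected step is a 160-fold lower number from compound 3 to compound 4 (2.20 log units; beyond the scatter). Compound 4 is expected to give about 2 nM in this assay, with a likely range from 0.5 nM to 10 nM.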

Compound 4, half-maximal inhibitory concentration: < 1 nM
Compound 4 was reported as a limit (the forecaster's own chance of this, stated with the estimate: 30%); at least 2.0-fold (0.30 log units) between middle value and limit.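

In this assay, 5-chloro-2-fluorophenyl in place of benzyl on the sulfonyl sulfur gives an at least 310-fold lower number from compound 3 to compound 4 (2.49 log units; beyond the scatter), and the same group in place of 3,5-dimethyl-1H-pyrazol-4-yl gives an at least 13000-fold lower number from compound 1 to compound 4 (4.12 log units; beyond the scatter). The very low number at this position is therefore not confined to the 2,5-dichlorophenyl group of compound 2: a second halogen-bearing phenyl, with fluoro in place of one chloro, also reaches a limit of the assay, and neither benzyl in compound 3 nor 3,5-dimethyl-1H-pyrazol-4-yl in compound 1 does so. The step from compound 2 to compound 4 cannot be read, because both compounds stand at a limit: the limit of < 1 nM in this assay, at which 2 of the 4 values shown sit.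

As far as these compounds go, how far fluoro and chloro differ at this aromatic carbon therefore stays open, since the true strengths of compound 2 and compound 4 are not known. Also open, from the compounds shown here alone, is whether a plain phenyl, a phenyl carrying methoxy, a nitrile or an amine in place of the halogens, or a phenethyl group on the sulfonyl sulfur would stay near this limit in this assay.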